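Bromo for Chloro on the Outer Phenyl Ring

The source may report more compounds than this note shows. Statements on the series, on what has been measured and on what is new or still open speak of the compounds shown alone.

Compound 1 `O=C1NC(=O)/C(=C/c2ccc(OCCSc3nnc(-c4ccccc4)[nH]3)cc2)S1` was tested in a functional assay on the whole organism (strain Wistar) with Rattus norvegicus as the target, with a stated time of 15 days, at a dose of 100 mg/kg by the oral route (on this read-out lower numbers stand for a weaker effect and higher numbers for a stronger effect at the one dose given), where compound 1 gives 38.9%. Compound 2 `O=C1NC(=O)/C(=C/c2ccc(OCCSc3nnc(-c4ccc(Cl)cc4)[nH]3)cc2)S1` carries a chloro group on its outer phenyl ring, and in this assay compound 2 gives 41.6%. Among the compounds with values here, the one measured step, a number 2.7 percentage points higher from compound 1 to compound 2 (within the scatter), is within the usual scatter, so the two numbers cannot be told apart; compound 2 simply sits alongside compound 1 with nothing between them that a repeat measurement might not reverse.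

Compound 3 `O=C1NC(=O)/C(=C/c2ccc(OCCSc3nnc(-c4ccc(Br)cc4)[nH]3)cc2)S1` is the next step outward: bromo in place of chloro on an aromatic carbon. Within the data shown here, no measured pair shows what exchanging one halogen for another does here. Among the measured compounds shown here, the only related step, a number 2.7 percentage points higher from compound 1 to compound 2 (within the scatter), shows that putting a halogen onto this ring at all left the read-out essentially unchanged. On that basis the exchange of chloro for bromo is expected to give a step of about a number 0.4 percentage points higher from compound 2 to compound 3 (within the scatter), that is, no change beyond the scatter. Compound 3 is therefore estimated at 42%, with a likely range from 30% to 55%.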

Compound 3, a percentage reported as activity, at one dose (the size of the read-out at that dose, not a potency): 45.7%
The estimate for compound 3 lay 3.7 percentage points below the measured number; the measured number falls inside the stated range.
By their numbers in this assay, from the lowest: compounds 1, 2 and 3 (each within the scatter of the next).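

In this assay the exchange of chloro for bromo gives a direct comparison of two halogens at this place on the outer phenyl ring, and it reads a number 4.1 percentage points higher from compound 2 to compound 3 (within the scatter) with no change that can be told apart from repeat-to-repeat variation. The comparison of bromo with plain hydrogen, a step of a number 6.8 percentage points higher from compound 1 to compound 3 (within the scatter) on the same ring carbon, is also no real difference, so hydrogen, chloro and bromo at this carbon, para to a large group, cannot be separated by this read-out at the single dose given. No supporting measurement is available that could explain why these three compounds read alike.

As far as these compounds go, whether this position tolerates any group at all, or only these small atoms, remains open, since a methoxy group, an amine or a carboxylic acid on the same carbon could still move the number well beyond the scatter. Also open, from the compounds shown here alone, is whether the same halogens on another carbon of this ring, or changes to the shared core, would separate compounds that here look the same.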